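Replacing Naphthyl with Nitrophenyl on a Weakly Cytotoxic Core

A few compounds are considered here, and "the series" means these few. Any claim that something is new, unique, unknown or untested is made for them only; others in the source may bear on it.

Measured so far:
Compound 1 `COc1cc(-c2nnc3n2NC(c2ccco2)C(C(=O)c2ccccc2F)S3)cc(OC)c1OC` gives 78700 nM in a functional assay on A549 cells (Homo sapiens) for cytotoxicity, read by MTT assay, with a stated time of 48 h; a higher number here means a weaker inhibitor, a lower number a stronger inhibitor.
Compound 2 `COc1cc(-c2nnc3n2NC(c2ccco2)C(C(=O)c2cccc4ccccc24)S3)cc(OC)c1OC` gives > 100000 nM in this assay.

For compound 2 that figure is only a limit of the assay, not a number; it sits at the limit of > 100000 nM in this assay, at which 1 of the 2 values shown sits. The change 4-nitrophenyl in place of naphthalen-1-yl on a carbonyl carbon gives compound 3 `COc1cc(-c2nnc3n2NC(c2ccco2)C(C(=O)c2ccc([N+](=O)[O-])cc2)S3)cc(OC)c1OC`. Among the measured compounds shown here, the single measured step, an at least 1.2-fold higher number from compound 1 to compound 2 (0.10 log units; that floor lies within the scatter), is a different replacement on a carbonyl carbon and lies within the scatter, so no shift beyond the scatter is expected here. The expected step is an at least 1.1-fold lower number from compound 2 to compound 3 (0.04 log units; that floor lies within the scatter). Compound 3 is estimated at 90000 nM, ranging from 40000 nM to 200000 nM.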

Compound 3, half-maximal inhibitory concentration: > 100000 nM
Compound 3 gave a limit, no number; the forecaster's own chance of this, stated with the estimate: 50%; middle value at least 1.1-fold (0.04 log units) from the limit.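

For compound 3, with 4-nitrophenyl on the carbonyl carbon, the result is a limit and not a number, as it was with naphthalen-1-yl: the limit of > 100000 nM in this assay, at which 2 of the 3 values shown sit.

The step between the two limits cannot be read. Among the compounds shown here, the one readable step is an at least 1.2-fold higher number from compound 1 to compound 3 (0.10 log units; that floor lies within the scatter), so a second replacement of 2-fluorophenyl also shows no shift beyond the scatter.

Going by these compounds, what 4-aminophenyl or 4-carboxyphenyl would give on this carbonyl carbon stays open. So does whether any group here can bring a number clearly lower than that of compound 1.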